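Naphthalenyl replacement at the aryl position of compound 2

This account rests on a few compounds, and the source may have more. Where it says the series, first, only, none or still open, it means among the compounds named here.

Compound 2 `Fc1ccc(Cc2ccc3c(NCCCNCc4ccco4)ccnc3c2)c(Cl)c1` gives 4200 nM in a physicochemical assay for solubility, with a stated time of 18 h, at pH 7.4 (on this read-out lower numbers stand for lower solubility and higher numbers for higher solubility), the lower of the two numbers shown; compound 1 `CN(C)c1cccc(Oc2ccc3c(NCCCNCc4ccco4)ccnc3c2)c1` gives 14500 nM. Going by the values given here, the one measured step at this position, a 3.5-fold lower number from compound 1 to compound 2 (0.54 log units; beyond the scatter), went downward. Compound 3 `c1coc(CNCCCNc2ccnc3cc(-c4cccc5ccccc45)ccc23)c1` differs from compound 2 by naphthalen-1-yl in place of 2-chloro-4-fluorobenzyl on an aromatic carbon. Among the compounds with values here, no measured step covers a naphthalen-1-yl group, so the expectation rests only on the direction seen from compound 1 to compound 2. Compound 3 is therefore expected to show a modest further drop, a 2.3-fold lower number from compound 2 to compound 3 (0.37 log units; beyond the scatter), giving an estimated 1800 nM with a range of 400 nM to 8000 nM.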

Compound 3, solubility: 32000 nM
For compound 3 the middle estimate is 18-fold (1.25 log units) below the measured one, outside the stated range (above it).
By their numbers in this assay, from the lowest: compound 2; then compound 1; then compound 3.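

In this assay this aromatic carbon does not push the number only one way: the downward step seen earlier is reversed, with a 7.6-fold higher number from compound 2 to compound 3 (0.88 log units; beyond the scatter), and naphthalen-1-yl also exceeds the 3-(dimethylamino)phenoxy group, with a 2.2-fold higher number from compound 1 to compound 3 (0.34 log units; beyond the scatter). Compound 3 therefore has the highest number of the three, carrying two six-membered aromatic rings of carbon only in place of one. No supporting measurement bears on what lies behind this rise.

On these data alone, whether a pyridine ring or a morpholine at this place would stand nearer compound 2 or compound 3 remains open. So does whether a second naphthalene attachment point, such as naphthalen-2-yl, would give a similar number.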